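Ethyl in Place of Chloro on the Aromatic Ring

A few compounds are considered here, and "the series" means these few. Any claim that something is new, unique, unknown or untested is made for them only; others in the source may bear on it.

Compound 1, `COc1cc(-c2noc(Cc3c[nH]c4ccccc34)n2)cc(OC)c1OC`, gives 2800 nM in a functional assay on cells (Splenocyte, Mus musculus, strain BALB/c) for inhibition, read by scintillation counting and thymidine incorporation, with stated times of 48 h and 8 h; on this read-out lower numbers stand for stronger inhibition and higher numbers for weaker inhibition. Compound 2, `c1ccc(-c2noc(Cc3c[nH]c4ccccc34)n2)cc1`, reaches only the limit of the assay, > 50000 nM, rather than a number. Compound 3, `Clc1ccc(-c2noc(Cc3c[nH]c4ccccc34)n2)cc1`, likewise stands at a limit, > 50000 nM, and so belongs to the limit of > 50000 nM in this assay, at which 2 of the 3 values shown sit. Among the measured compounds shown here, the single step between compounds, a step that the two limits leave unreadable from compound 2 to compound 3, is therefore unreadable. Compound 4, `CCc1ccc(-c2noc(Cc3c[nH]c4ccccc34)n2)cc1`, differs from compound 3 by ethyl in place of chloro on an aromatic carbon. For the measured compounds named here, no measured step reads on this change: the only step, from compound 2 to compound 3, shows nothing about size, and compound 3 itself offers only a limit. The expectation for compound 4 in this assay is accordingly that it stays at or near the limit, with an estimated step that the limit leaves unreadable from compound 3 to compound 4 that may not be readable at all. Compound 4 is expected to give about 60000 nM, within a range from 15000 nM to 250000 nM.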

Compound 4, half-maximal inhibitory concentration: 13900 nM
Estimate against measurement, compound 4: 4.3-fold (0.64 log units) above, and the stated range ends above it.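

At the aromatic carbon para to a large group, ethyl gives compound 4 a readable number in this assay, which neither hydrogen nor chloro at this place had given. Ethyl in place of chloro gives an at least 3.5-fold lower number from compound 3 to compound 4 (0.55 log units; beyond the scatter), and ethyl in place of hydrogen gives an at least 3.5-fold lower number from compound 2 to compound 4 (0.55 log units; beyond the scatter), so this place on the ring can alter the read-out beyond the scatter. Both steps start from a limit, so their full size cannot be read, and the step between the hydrogen and chloro compounds cannot be read at all: the limit of > 50000 nM in this assay, at which 2 of the 4 values shown sit.

From the compounds shown here alone, whether a longer chain such as propyl, or an amine, at this same place would lower the number further remains open. Going by these compounds, compound 1 differs from compound 4 in more than one place, so how its value relates to the ethyl change also remains open.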